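Shortening the alkyl chain on a diaryl urea

This account rests on a few compounds, and the source may have more. Where it says the series, first, only, none or still open, it means among the compounds named here.

compound 1 `CCCCCCCc1ccc(NC(=O)Nc2c(C(C)C)cccc2C(C)C)cc1`: 19 nM
compound 2 `CCCCCCCCCCCCCc1ccc(NC(=O)Nc2c(C(C)C)cccc2C(C)C)cc1`: 11 nM

In an assay on isolated protein for inhibition of acyl-CoA:cholesterol acyltransferase (Oryctolagus cuniculus) (on this read-out higher numbers stand for weaker inhibition and lower numbers for stronger inhibition), compound 2 gives 11 nM and compound 1 gives 19 nM; the two numbers lie within the scatter of each other, as the step of a 1.7-fold lower number from compound 1 to compound 2 (0.24 log units; within the scatter) shows. Compound 3 `CCCCCCCCCCc1ccc(NC(=O)Nc2c(C(C)C)cccc2C(C)C)cc1` differs from compound 2 by hydrogen in place of propyl on a saturated chain carbon, ten or more bonds along the chain from an aromatic carbon. Among the measured compounds shown here, the only measured step that bears on this change is a 1.7-fold lower number from compound 1 to compound 2 (0.24 log units; within the scatter), which went with a lengthening of the chain and stayed within the scatter; the change to compound 3 runs the other way and only partway back toward compound 1. On that basis compound 3 is expected to sit between the two measured values, and the step of a 1.3-fold higher number from compound 2 to compound 3 (0.10 log units; within the scatter) is expected to stay within the scatter. Compound 3 is therefore estimated at 14 nM in this assay, with a range from 7 nM to 28 nM.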

Compound 3, half-maximal inhibitory concentration: 13 nM
Compound 3: middle estimate off by 1.1-fold (0.03 log units), on the high side; the range from low to high includes it.
By their numbers in this assay, from the lowest: compounds 2, 3 and 1 (each within the scatter of the next).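

In this assay, the step of a 1.2-fold higher number from compound 2 to compound 3 (0.07 log units; within the scatter) shows that hydrogen in place of propyl on a saturated chain carbon stays within the scatter. The step of a 1.5-fold lower number from compound 1 to compound 3 (0.16 log units; within the scatter) likewise stays within the scatter, so the third chain length separates from neither of the other two and all three compounds form one group on this read-out. No supporting measurement bears on why these numbers stay together.

The compounds shown leave open whether a much shorter group, such as methyl or ethyl, in place of these chains would stay within the scatter of compounds 1, 2 and 3. They also leave open whether a chain carrying an amine or a carboxylic acid would do so.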